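Removing a Methyl from a Phthalimide-Thiazole Pair

A few compounds are considered here, and "the series" means these few. Any claim that something is new, unique, unknown or untested is made for them only; others in the source may bear on it.

Measured compounds:
compound 1, `Cc1cnc(N2C(=O)c3ccccc3C2=O)s1`, > 200000 nM
compound 2, `Cc1ccc2c(c1)C(=O)N(c1nccs1)C2=O`, > 200000 nM

Both measured values sit at the limit of the assay. In a functional assay on HepG2 cells (Homo sapiens) for cytotoxicity, read by MTT assay, with a stated time of 48 h (on this read-out lower numbers stand for stronger inhibition and higher numbers for weaker inhibition), compound 1 gives > 200000 nM, a limit rather than a number. In this assay compound 2 likewise gives > 200000 nM, again a limit. Compound 2 therefore stands where every value shown stands, as the limit of > 200000 nM in this assay, at which 2 of the 2 values shown sit, records. Compound 3, `O=C1c2ccccc2C(=O)N1c1nccs1`, differs from compound 2 by hydrogen in place of methyl on an aromatic carbon. For the measured compounds named here, no step between measured compounds is available to size this change. With two values at the limit, the expected step from compound 2 to compound 3 in this assay is none beyond the usual scatter, that is a step that the limit leaves unreadable from compound 2 to compound 3. Compound 3 is accordingly expected at about 300000 nM, within 100000 nM to 1000000 nM, and is expected most probably to return another limit.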

Compound 3, half-maximal inhibitory concentration: > 200000 nM
Compound 3 ended at the assay's limit (the forecaster's own chance of this, stated with the estimate: 85%); the middle value is on the limit's open side.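

Neither the step from compound 2 to compound 3 nor the step from compound 1 to compound 3 can be read in this assay, since all three values are limits: the limit of > 200000 nM in this assay, at which 3 of the 3 values shown sit.

The compounds shown leave open whether removing a methyl from either compound changes the read-out at all.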